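The compounds below may be only part of what the source reports. "The series", "measured", "known", "first", "only" and "open" are said of these compounds alone.

Compound 1 `COC(=O)c1nc(C)n(-c2ccc(C(F)(F)F)cc2)n1`: 9100 nM
Compound 2 `COC(=O)c1nc(C2CCCC2)n(-c2ccc(F)cc2)n1`: 9550 nM

In a functional assay on Jurkat cells (Homo sapiens) for inhibition, read by MTT assay, with a stated time of 72 h (on this read-out higher numbers stand for weaker inhibition of growth and lower numbers for stronger inhibition of growth), compound 2 gives 9550 nM, and in this assay compound 1 gives 9100 nM; the two numbers sit within the scatter of each other, so neither compound is set apart from the other. Compound 3 `COC(=O)c1nc(C2CCCC2)n(-c2ccc(C(F)(F)F)cc2)n1` differs from compound 2 by trifluoromethyl in place of fluoro on an aromatic carbon. Within the data shown here, no measured pair isolates this change on its own, so its size is not known from these data. The step from compound 2 to compound 3 is expected to be small, a 1.3-fold lower number from compound 2 to compound 3 (0.10 log units; within the scatter), without a clear direction beyond the scatter. Compound 3 is estimated at 7500 nM, with a range from 2500 nM to 25000 nM.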

Compound 3, concentration for 50% growth inhibition: > 100000 nM
Compound 3 gave a limit, no number; the forecaster's own chance of this, stated with the estimate: 10%; middle value at least 13-fold (1.12 log units) away from the limit.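

In this assay compound 3 gives a limit and not a number: the limit of > 100000 nM in this assay, at which 1 of the 3 values shown sits.
Trifluoromethyl in place of fluoro, para to a large group, gives an at least 10-fold higher number from compound 2 to compound 3 (1.01 log units; beyond the scatter), so this position is not indifferent to the change when cyclopentyl is present. Cyclopentyl in place of methyl gives an at least 10-fold higher number from compound 1 to compound 3 (1.04 log units; beyond the scatter), a separation that the two earlier compounds, within the scatter of each other, did not show.

The compounds shown leave open whether this step depends on trifluoromethyl and cyclopentyl occurring together. They also leave open how an amine or a carboxylic acid at this aromatic carbon would read.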